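The source may report more compounds than this note shows. Statements on the series, on what has been measured and on what is new or still open speak of the compounds shown alone.

Measured compounds:
compound 1 `O=S(=O)(/C=C/c1ccccc1)Nc1ccccc1` gives 10000 nM
compound 2 `COc1cc(OC)c(/C=C/S(=O)(=O)Nc2ccc(OC)c(OP(=O)(O)O)c2)c(OC)c1` gives 40 nM

In a functional assay on DU-145 cells (Homo sapiens) for cytotoxicity, read by trypan blue exclusion, with a stated time of 96 h (on this read-out higher numbers stand for weaker inhibition and lower numbers for stronger inhibition), compound 2 gives 40 nM and holds the lowest number of the two, while compound 1 gives 10000 nM, a gap that lies beyond the usual scatter. Compound 3 `COc1cc(OC)c(/C=C/S(=O)(=O)Nc2ccc(OC)c(NC(C(=O)O)c3ccc(Cl)cc3)c2)c(OC)c1` has not yet been measured. It differs from compound 2 in one place: a group of 12 heavy atoms (8 carbon, 1 nitrogen, 2 oxygen, 1 chlorine; one six-membered aromatic ring of carbon only) in place of a group of 5 heavy atoms (4 oxygen, 1 phosphorus; no ring), on an aromatic carbon The change sits on an aromatic carbon of a six-membered aromatic ring of carbon only, ortho to a methoxy group and meta to a large group. Among the compounds with values here, no measured pair shows this change, so its effect is unknown. A large replacement of this kind is expected to cost some potency, and the step from compound 2 to compound 3 is estimated at a 7.5-fold higher number from compound 2 to compound 3 (0.88 log units; beyond the scatter). Compound 3 is therefore expected to give 300 nM, within a range of 40 nM to 3000 nM.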

Compound 3, half-maximal inhibitory concentration: 75 nM
Beside the measured number, compound 3's estimate is 4.0-fold (0.60 log units) above it, within the range that was stated.
By their numbers in this assay, from the lowest: compounds 2 and 3 (each within the scatter of the next); then compound 1.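

In this assay, the aromatic carbon ortho to a methoxy group carries the (carboxy(4-chlorophenyl)methyl)amino group in compound 3 and the phosphorus-bearing group in compound 2, with a 1.9-fold higher number from compound 2 to compound 3 (0.27 log units; within the scatter). Within the data shown here, this position therefore accepts a group of 12 heavy atoms with a six-membered aromatic ring, whereas the earlier compounds showed only the group of 5 heavy atoms with no ring, and the two numbers cannot be told apart. No measurement shown here accounts for this result.

From the compounds shown here alone, it remains open which part of the entering group, the carboxy group, the 4-chlorophenyl group or the amino link, carries the result. Going by these compounds, it is also open whether a simple amine or hydroxyl group at this position, or a fluorine in place of the chlorine, would give a similar number.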